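Removing the bromine from compound 1: what to expect

A few compounds are considered here, and "the series" means these few. Any claim that something is new, unique, unknown or untested is made for them only; others in the source may bear on it.

Compound 1 `Brc1ccc(C2=NN(C3=NC(c4ccccc4)CS3)C(c3ccc4ccccc4c3)C2)cc1` sits between its two neighbours on the numbers at hand. In a functional assay on HeLa cells (Homo sapiens) for inhibition, read by CCK-8 assay, with a stated time of 48 h (a lower number here means a stronger inhibitor, a higher number a weaker inhibitor), compound 1 gives 4960 nM. Compound 2 `O=C1CSC(N2N=C(c3ccc(Br)cc3)CC2c2ccc3ccccc3c2)=N1` gives 4220 nM in this assay, and compound 3 `Brc1ccc(C2=NN(C3=NC(c4ccccc4)CS3)C(c3cccc4ccccc34)C2)cc1` gives 6650 nM; the step of a 1.2-fold lower number from compound 1 to compound 2 (0.07 log units; within the scatter) and the step of a 1.3-fold higher number from compound 1 to compound 3 (0.13 log units; within the scatter) both stay within the scatter, so the three compounds cannot be told apart.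

Compound 4 `c1ccc(C2=NN(C3=NC(c4ccccc4)CS3)C(c3ccc4ccccc4c3)C2)cc1` differs from compound 1 in one place: hydrogen in place of bromo on an aromatic carbon. Cut one bond further out, the change reads 4-bromophenyl to phenyl. Neither measured step touches this part of the shared core, so no direct guide exists for the size of this change. The two measured steps show that small alterations elsewhere on this core leave the number roughly where it was. On that basis the step of a 1.2-fold higher number from compound 1 to compound 4 (0.08 log units; within the scatter) is expected to stay within or only slightly beyond the scatter. Compound 4 is therefore estimated at 6000 nM, with a range from 2500 nM to 14000 nM.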

Compound 4, half-maximal inhibitory concentration: 3860 nM
Compound 4: the middle estimate sits 1.6-fold (0.19 log units) above what was measured; the measured number falls inside the stated range.
By their numbers in this assay, from the lowest: compounds 4, 2, 1 and 3 (each within the scatter of the next).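

For the compounds shown here, this is the first direct look at the bromo on the aromatic ring. Taking it off gives a 1.3-fold lower number from compound 1 to compound 4 (0.11 log units; within the scatter) in this assay, so compound 1 and compound 4 cannot be told apart, and the bromo is not required for the activity seen with compound 1 on these numbers. No measurement shown here bears on why the number stays in place when hydrogen replaces bromo.

The compounds shown leave open whether any group on this aromatic carbon, para to a large group, can move the number beyond the scatter, since only bromo and hydrogen appear there; an amine or a carboxylic acid would test this. Also open, going by these compounds, is whether the same swap would behave alike with the naphthalen-1-yl group of compound 3.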